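This account rests on a few compounds, and the source may have more. Where it says the series, first, only, none or still open, it means among the compounds named here.

Measured compounds:
- compound 1 `Cc1cn([C@@H]2O[C@H](CO[Si](C)(C)C(C)(C)C)[C@@]3(OS(=O)(=O)C=C3NC(=O)Nc3ccccc3)[C@H]2O[Si](C)(C)C(C)(C)C)c(=O)n(C)c1=O` gives 1400 nM in an ADME assay on HEL cells (Homo sapiens) for cytotoxicity, with a stated time of 3 days; on this read-out higher numbers stand for lower toxicity in this test and lower numbers for higher toxicity in this test
- compound 2 `Cc1cn([C@@H]2O[C@H](CO[Si](C)(C)C(C)(C)C)[C@@]3(OS(=O)(=O)C=C3NC(=O)N(C(=O)Nc3ccccc3)c3ccccc3)[C@H]2O[Si](C)(C)C(C)(C)C)c(=O)n(C)c1=O` gives 46000 nM in this assay

Going by the values given here, compound 1 holds the lowest of the two numbers in this assay; the only other measured compound, compound 2, stands at a higher number, and the step of a 33-fold higher number from compound 1 to compound 2 (1.52 log units; beyond the scatter) is well beyond the scatter. That step adds a phenylcarbamoyl to the amide-type nitrogen, so it enlarges the compound.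

The step to compound 3 `Cc1cn([C@@H]2O[C@H](CO[Si](C)(C)C(C)(C)C)[C@@]3(OS(=O)(=O)C=C3NC(N)=O)[C@H]2O[Si](C)(C)C(C)(C)C)c(=O)n(C)c1=O` runs the other way: hydrogen in place of phenyl on an amide-type nitrogen. Among the compounds with values here, no measured pair shows the loss of a phenyl at this position, so the step from compound 1 to compound 2 bears on it only indirectly, as the one sign that the read-out in this assay is sensitive to what sits on this nitrogen. Within the data shown here, the extra group in compound 2 moved the number upward; removing the phenyl is a smaller change, and no step of its kind is available. The expected step of a 1.8-fold higher number from compound 1 to compound 3 (0.25 log units; within the scatter) is therefore taken as a modest rise at most, plausibly within the scatter.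

Compound 3 is estimated at 2500 nM in this assay, with a range of 600 nM to 12000 nM.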

Compound 3, minimum cytotoxic concentration: 16000 nM
Compound 3: the middle estimate sits 6.4-fold (0.81 log units) below what was measured; measured number outside the range, above it.
By their numbers in this assay, from the lowest: compound 1; then compound 3; then compound 2.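

In this assay, hydrogen in place of phenyl on an amide-type nitrogen gives an 11-fold higher number from compound 1 to compound 3 (1.06 log units; beyond the scatter) and is read as a large step, so removing a group at this position moves the number on its own, with no new group entering. The earlier step of a 33-fold higher number from compound 1 to compound 2 (1.52 log units; beyond the scatter) added phenylcarbamoyl to the same nitrogen, and it also led to a higher number, which here stands for lower toxicity in this test. Among these three compounds, both the smaller and the larger substituent pattern therefore lie above compound 1, so the number does not follow a simple order of group size at this nitrogen, and nothing at hand gives a reason for either step.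

The compounds shown leave open whether the low number of compound 1 depends on the phenyl ring as such or on any group of similar size on this nitrogen. A methyl, a benzyl or a phenyl ring carrying a chlorine atom in place of the phenyl would bear on that question, and so would a hydrogen in place of the silyl groups of the shared core.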